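A few compounds are considered here, and "the series" means these few. Any claim that something is new, unique, unknown or untested is made for them only; others in the source may bear on it.

Compound 1 `COc1cc(C(=O)C2Sc3nnc(-c4cc(OC)c(OC)c(OC)c4)n3NC2c2ccco2)cc(OC)c1OC` carries a 3,4,5-trimethoxyphenyl on the carbonyl carbon of the shared core. In a functional assay on A549 cells (Homo sapiens) for cytotoxicity, read by MTT assay, with a stated time of 48 h (a lower number here means a stronger inhibitor, a higher number a weaker inhibitor), compound 1 gives 48300 nM. Compound 2 `COc1cc(-c2nnc3n2NC(c2ccco2)C(C(=O)c2cccc4ccccc24)S3)cc(OC)c1OC` bears naphthalen-1-yl in that place. In this assay compound 2 reaches only > 100000 nM, which is a limit of the assay and not a number. Among the measured compounds shown here, the single measured step, an at least 2.0-fold higher number from compound 1 to compound 2 (0.31 log units; beyond the scatter), is therefore known only as a lower bound, since the limit of > 100000 nM in this assay, at which 1 of the 2 values shown sits, is where compound 2 sits. Compound 3 `COc1cc(-c2nnc3n2NC(c2ccco2)C(C(=O)c2ccc(-c4ccccc4)cc2)S3)cc(OC)c1OC` has not yet been measured; it differs from compound 2 by 4-phenylphenyl in place of naphthalen-1-yl on a carbonyl carbon. For the measured compounds named here, only the step from compound 1 to compound 2 bears on this change, and it shows that exchanging the aryl on the carbonyl carbon can weaken inhibition. Compound 3 is expected to show a step of a number no higher from compound 2 to compound 3 (the limit leaves the size open), which is not expected to exceed the scatter. Compound 3 is estimated at 100000 nM, within 40000 nM to 300000 nM.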

Compound 3, half-maximal inhibitory concentration: > 100000 nM
Compound 3: no number, only a limit (the forecaster's own chance of this, stated with the estimate: 60%); the middle value sits exactly at the limit.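

Exchanging the 3,4,5-trimethoxyphenyl on the carbonyl carbon for 4-phenylphenyl gives an at least 2.0-fold higher number from compound 1 to compound 3 (0.31 log units; beyond the scatter). In this assay, the weakening seen with naphthalen-1-yl therefore appears with a second group of two carbon-only six-membered aromatic rings, differently joined. The step between these two groups cannot be read, and neither can be placed against the other, since compound 2 and compound 3 both stop at a limit of the assay and not at a number: the limit of > 100000 nM in this assay, at which 2 of the 3 values shown sit.

As far as these compounds go, with compound 1 the only one of the three giving a number, it remains open which of the methoxy groups on its 3,4,5-trimethoxyphenyl matter at this position. Also open, from the compounds shown here alone, is whether a phenyl carrying an amine or a carboxylic acid on the carbonyl carbon would give a readable number.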